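The source may hold more compounds than are shown below. What is called first, only, known or untested is meant among the compounds shown, and "the series" means these compounds.

Measured so far:
compound 1 `CC1=CC(C)(C)N(Cc2ccc(C)cc2)c2ccc(O)cc21` — 8100 nM
compound 2 `CC(=O)Oc1ccc2c(c1)C(C)=CC(C)(C)N2Cc1ccccc1` — 24000 nM

Within the data shown here, in an ADME assay on L6 cells (Rattus norvegicus) for cytotoxicity, read by resazurin assay, with a stated time of 70 h (on this read-out lower numbers stand for stronger inhibition and higher numbers for weaker inhibition), compound 2 gives 24000 nM, the higher of the two numbers so far. Compound 1 gives 8100 nM, and the gap between these two lies beyond the scatter of repeat measurements. Among the measured compounds shown here, no pair of compounds differing in a single place has been measured, so no step is available to guide the next one.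

Compound 3 `COc1ccc(CN2c3ccc(OC(C)=O)cc3C(C)=CC2(C)C)cc1` is to be measured in this assay. It differs from compound 2 by methoxy in place of hydrogen on an aromatic carbon. Without a comparable step in hand, the expected change from compound 2 to compound 3 is a 1.2-fold lower number from compound 2 to compound 3 (0.08 log units; within the scatter), taken as lying within the scatter of this assay. For compound 3 the estimate is 20000 nM, with a range from 8000 nM to 50000 nM to cover the unknown effect of the added group.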

Compound 3, half-maximal inhibitory concentration: 15000 nM
Beside the measured number, compound 3's estimate is 1.3-fold (0.12 log units) above it, within the range that was stated.
By their numbers in this assay, from the lowest: compounds 1, 3 and 2 (each within the scatter of the next, the first and the last beyond it).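

In this assay, the change from phenyl to 4-methoxyphenyl, with methoxy placed para to a large group, gives a 1.6-fold lower number from compound 2 to compound 3 (0.20 log units; within the scatter), so compound 2 and compound 3 cannot be told apart at this position. Among these compounds, this is the first single-place comparison, and it shows that adding methoxy here produces no change beyond the scatter. No information available here bears on the reason for this result.

From the compounds shown here alone, it remains open whether an amine, a carboxylic acid or a longer chain at this same carbon would also stay within the scatter, and whether methoxy would behave alike on other carbons of that ring. Going by these compounds, the separate effect of the acetyloxy group against the free hydroxy group seen in compound 1 also remains open.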